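A few compounds are considered here, and "the series" means these few. Any claim that something is new, unique, unknown or untested is made for them only; others in the source may bear on it.

Measured compounds:
compound 1 `COc1cc(C)cc(-c2nn(CC#N)cc2-c2ccc(-c3cccc(C(C)=O)c3)nc2)c1` — 2230 nM
compound 2 `Cc1cc(O)cc(-c2nn(CC#N)cc2-c2ccnc(-c3ccc(Oc4ccccc4)cc3)c2)c1` — 1920 nM

Among the compounds with values here, in a functional assay on KM12 cells (Homo sapiens) for inhibition, read by sulforhodamine B assay, with a stated time of 48 h (a lower number here means a stronger inhibitor of growth, a higher number a weaker inhibitor of growth), compound 2 gives 1920 nM, the lower of the two numbers so far; compound 1 gives 2230 nM, and the gap between them lies within the scatter, so neither can be set apart from the other. Within the data shown here, no pair of measured compounds differs in a single place, so no step has been observed yet in this assay.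

Compound 3 `Cc1cc(O)cc(-c2nn(CC#N)cc2-c2ccnc(-c3ccc(N(C)C)cc3)c2)c1` has not been measured. It differs from compound 2 by dimethylamino in place of phenoxy on an aromatic carbon. Among the measured compounds shown here, no measured step speaks to this change, so the direction is open; a move of modest size in either sense, possibly none beyond the scatter, is the working expectation. Compound 3 is estimated at 2500 nM in this assay, with a range from 800 nM to 8000 nM, which means an expected step of a 1.3-fold higher number from compound 2 to compound 3 (0.11 log units; within the scatter).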

Compound 3, concentration for 50% growth inhibition: 1630 nM
Beside the measured number, compound 3's estimate is 1.5-fold (0.19 log units) above it, within the range that was stated.
By their numbers in this assay, from the lowest: compounds 3, 2 and 1 (each within the scatter of the next).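

Notes on the aromatic carbon para to a large group: in this assay, dimethylamino in place of phenoxy gives a 1.2-fold lower number from compound 2 to compound 3 (0.07 log units; within the scatter). Within the data shown here, this is the first single-place step, and it shows that phenoxy, with its 7 heavy atoms and six-membered aromatic ring, and dimethylamino, with 3 heavy atoms and no ring, cannot be told apart at this position in this read-out. No measurement at hand offers an explanation for this result.

The compounds shown leave open whether any substituent at this position can move the number beyond the scatter, since only these two groups are compared there. A carboxylic acid, a primary amine or a morpholine at the same carbon would test this, as would a bare hydrogen.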